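One cytotoxicity value and a side-chain exchange

The source may report more compounds than this note shows. Statements on the series, on what has been measured and on what is new or still open speak of the compounds shown alone.

Among the measured compounds shown here, the series so far holds two compounds read in an ADME assay on NIH3T3 cells (Mus musculus) for cytotoxicity; on this read-out lower numbers stand for higher toxicity in this test and higher numbers for lower toxicity in this test. Compound 1 (`Fc1cccc(COc2ccc(Nc3ncnc4sc(C#CCN5CCCC5)cc34)cc2Cl)c1`) has no usable result, and its entry reads "not determined" (no result reported). For the measured compounds named here, compound 2 (`CN1CCN(CC#Cc2ccc3ncnc(Nc4ccc(OCc5cccc(F)c5)c(Cl)c4)c3c2)CC1`) gives 7.2 uM, the only number in hand, so compound 2 cannot yet be placed against any other compound and no measured step exists.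

Compound 3 (`CCOC(=O)CN(C)CC#Cc1ccc2ncnc(Nc3ccc(OCc4cccc(F)c4)c(Cl)c3)c2c1`) keeps the shared core and the alkyne chain of compound 2 and differs only at the end of that chain: ((ethoxycarbonyl)methyl)(methyl)amino in place of 4-methylpiperazin-1-yl on a saturated chain carbon bound to a triple-bonded carbon. Going by the values given here, the data hold no example of this exchange, or of any other, so the expectation rests on compound 2 at 7.2 uM alone. In this assay a small move toward higher numbers is expected, of a size close to the usual scatter, with no firm support for its direction. The estimated step is a 1.4-fold higher number from compound 2 to compound 3 (0.14 log units; within the scatter). For compound 3 the expected value is 10 uM, with an estimated range of 4 uM to 25 uM.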

Compound 3, half-maximal toxic concentration: > 50 uM
Compound 3 ended at the assay's limit; the forecaster's own chance of this, stated with the estimate: 15%; middle value at least 5.0-fold (0.69 log units) away from the limit.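

Working notes: the end of the alkyne chain is now the first place in the series with a readable step. In this assay, ((ethoxycarbonyl)methyl)(methyl)amino in place of 4-methylpiperazin-1-yl on a saturated chain carbon bound to a triple-bonded carbon gives an at least 6.9-fold higher number from compound 2 to compound 3 (0.84 log units; beyond the scatter), so the group at this position can shift the read-out beyond the scatter, which a single value could not show. The result for compound 3, > 50 uM, is a limit of the assay and not a number, so the step has a lower bound but no upper one: the limit of > 50 uM in this assay, at which 1 of the 3 values shown sits.

Among the compounds shown here, the change removes a ring and brings in an ester at the same time, and the single step does not separate the two, so an open-chain dimethylamino group and a carboxylic acid in place of the ethyl ester would be the informative neighbours. On these data alone, no property of either end group is measured here, and whether the step carries over to a different core remains open.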